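The source may report more compounds than this note shows. Statements on the series, on what has been measured and on what is new or still open speak of the compounds shown alone.

Compound 1 `N#Cc1ccccc1-c1ccc(CSc2ncnc3ccccc23)cc1` was examined in an assay on isolated protein for inhibition of phosphodiesterase 7 (Homo sapiens), read by scintillation proximity assay and cAMP accumulation, with a stated time of 1 h; a lower number here means a stronger inhibitor, a higher number a weaker inhibitor. In this assay compound 1 gives only a limit, > 100000 nM, and not a number. Compound 2 `CC(C)c1nc(SCc2ccc(-c3ccccc3C#N)cc2)c2ccccc2n1` differs from compound 1 by an isopropyl in place of hydrogen on an aromatic carbon. In this assay compound 2 likewise reaches only a limit, > 100000 nM. Among the measured compounds shown here, the one measured step, from compound 1 to compound 2, is therefore a step that the two limits leave unreadable from compound 1 to compound 2, because both values stand at the limit of > 100000 nM in this assay, at which 2 of the 2 values shown sit. Compound 1 thus stands at the edge of what this assay reports, with nothing around it that is read as a number.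

Compound 3 `N#Cc1ccccc1-c1ccc(CSc2nc(SCc3ccc(F)cc3)nc3ccccc23)cc1` carries the change ((4-fluorobenzyl)sulfanyl in place of hydrogen on an aromatic carbon). For the measured compounds named here, the only measured step bears on it weakly: it shows that a small alkyl group on the core left the limit in place, but gives no size. Going by the values given here, the larger, ring-bearing group entering in compound 3 has no measured counterpart here. The step from compound 1 to compound 3 is expected to be an at least 1.6-fold lower number from compound 1 to compound 3 (0.22 log units; that floor lies within the scatter), and compound 3 is estimated at 60000 nM in this assay, within 8000 nM to 300000 nM.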

Compound 3, half-maximal inhibitory concentration: > 100000 nM
Compound 3: a limit, no number (the forecaster's own chance of this, stated with the estimate: 55%); middle value at least 1.6-fold (0.22 log units) away from the limit.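

In this assay compound 3 gives > 100000 nM, a limit and not a number. No step among compound 1, compound 2 and compound 3 can be read, because all of them stand at the same place: the limit of > 100000 nM in this assay, at which 3 of the 3 values shown sit.

The compounds shown leave open whether any of these groups on the shared core changes inhibition at all.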